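Swapping an Amide for a Sulfonamide: Stability Outlook

The source may report more compounds than this note shows. Statements on the series, on what has been measured and on what is new or still open speak of the compounds shown alone.

Measured so far:
compound 1, `COc1ccc(-c2c(C)nc3c(N4CC[C@@H](NC(C)=O)C4)cc(Cl)nn23)cc1OC`: > 95%
compound 2, `CCCCCC(=O)N[C@@H]1CCN(c2cc(C)nn3c(-c4ccc(OC)c(OC)c4)c(C)nc23)C1`: > 95%

Compound 1 and compound 2 were examined in an ADME assay on microsomes from liver (Mus musculus) for metabolic stability, read by LC-MS, with NADPH named in the record, with a stated time of 60 min, tested at 1 uM, in the absence of a further agent; on this read-out lower numbers stand for a less stable compound and higher numbers for a more stable compound. For compound 1 the result is a limit of the assay rather than a number, > 95%. For compound 2 the result is likewise only a limit, > 95%. Both results sit at the limit of > 95% in this assay, at which 2 of the 2 values shown sit, so compound 2 cannot be placed above or below compound 1; all that can be said is that both are as stable as this assay can report.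

Compound 3, `COc1ccc(-c2c(C)nc3c(N4CC[C@@H](NS(=O)(=O)c5ccccc5)C4)cc(C)nn23)cc1OC`, has not yet been tested in this assay. It differs from compound 2 in one place: phenylsulfonyl in place of pentylcarbonyl on an amine nitrogen. Going by the values given here, no pair of measured compounds shows what such a change does here, so there is no measured step to lean on. For compound 2 the starting point is the limit > 95%. From there the expected step is a number at least 3 percentage points lower from compound 2 to compound 3 (that floor lies within the scatter), a small move downward, if anything beyond the usual scatter. Compound 3 is therefore estimated to give about 92%, most likely between 75% and 99%.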

Compound 3, percent of the compound remaining: > 95%
Compound 3: no number, only a limit; the forecaster's own chance of this, stated with the estimate: 55%; middle value at least 3 percentage points from the limit.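

In this assay compound 3 gives > 95%, which is a limit of the assay and not a number. Compound 2 also carries only a limit, so no step can be read from compound 2 to compound 3: the limit of > 95% in this assay, at which 3 of the 3 values shown sit. The compounds shown leave open whether phenylsulfonyl in place of pentylcarbonyl changes stability at all.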